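The source may report more compounds than this note shows. Statements on the series, on what has been measured and on what is new or still open speak of the compounds shown alone.

Measured compounds:
- compound 1 `CN(C)CCn1cnnc1-c1cc(Oc2ccc(NC(=O)N/N=C/c3cc(C(C)(C)C)cc(C(C)(C)C)c3O)cc2F)ccn1`: 3300 nM
- compound 2 `COc1ccc(/C=N/NC(=O)Nc2ccc(Oc3ccnc(-c4nncn4CCN(C)C)c3)c(F)c2)c(OC)c1`: 1680 nM
- compound 3 `CN(C)CCn1cnnc1-c1cc(Oc2ccc(NC(=O)N/N=C/c3ccc(O)c(Br)c3)cc2F)ccn1`: 1860 nM

All three were tested in a functional assay on MKN-45 cells (Homo sapiens) for cytotoxicity, read by MTT assay, with a stated time of 72 h; on this read-out lower numbers stand for stronger inhibition and higher numbers for weaker inhibition. Compound 3 gives 1860 nM, which is the second highest of the three numbers; compound 2 lies nearest, and compound 1 furthest, yet both gaps are within the scatter, so the three compounds cannot be told apart on these numbers.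

Compound 4 `CN(C)CCn1cnnc1-c1cc(Oc2ccc(NC(=O)N/N=C/c3ccc(F)cc3)cc2F)ccn1` is not yet measured. It differs from compound 3 in one place: 4-fluorophenyl in place of 3-bromo-4-hydroxyphenyl on a carbon with a double bond to nitrogen. Within the data shown here, the only measured step that bears on this is the one at the same place, where one aryl group was swapped for another: a 1.1-fold higher number from compound 2 to compound 3 (0.04 log units; within the scatter). That swap left the number essentially unchanged, and nothing in the data suggests the present swap should behave differently.

Compound 4 is therefore expected to give a number close to that of compound 3, with a step of a 1.2-fold higher number from compound 3 to compound 4 (0.09 log units; within the scatter), not beyond the scatter. The estimate for compound 4 in this assay is 2300 nM, within a range from 800 nM to 7000 nM.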

Compound 4, half-maximal inhibitory concentration: 1030 nM
Beside the measured number, compound 4's estimate is 2.2-fold (0.35 log units) above it; low and high end bracket the measured number.
By their numbers in this assay, from the lowest: compounds 4, 2, 3 and 1 (each within the scatter of the next, the first and the last beyond it).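

In this assay, 4-fluorophenyl in place of 3-bromo-4-hydroxyphenyl gives a 1.8-fold lower number from compound 3 to compound 4 (0.26 log units; within the scatter), and 4-fluorophenyl in place of 2,4-dimethoxyphenyl gives a 1.6-fold lower number from compound 2 to compound 4 (0.21 log units; within the scatter). The new group has no hydrogen-bond donor or acceptor, so at this position losing the donor and acceptor of 3-bromo-4-hydroxyphenyl brings no change that this assay can distinguish from scatter. The series also gains its first gap beyond the scatter, as compound 4 gives 1030 nM and compound 1 gives 3300 nM.

Nothing available explains why these numbers fall as they do. From the compounds shown here alone, it remains open whether a phenyl ring carrying an amine or a carboxylic acid, or a longer alkyl chain in place of the aryl group, would move the number beyond the scatter.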